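Alkyne substituents: thiophen-2-yl to phenyl

A few compounds are considered here, and "the series" means these few. Any claim that something is new, unique, unknown or untested is made for them only; others in the source may bear on it.

Measured in a functional assay on K562 cells (Homo sapiens) for antiproliferative activity, with a stated time of 72 h; on this read-out lower numbers stand for stronger inhibition and higher numbers for weaker inhibition:
- compound 1 `CCCC#Cc1cc([C@@H]2O[C@H](CO)[C@@H](O)[C@H]2O)n2ncnc(N)c12`: 1100 nM
- compound 2 `Nc1ncnn2c([C@@H]3O[C@H](CO)[C@@H](O)[C@H]3O)cc(C#CC3CC3)c12`: 40 nM
- compound 3 `Nc1ncnn2c([C@@H]3O[C@H](CO)[C@@H](O)[C@H]3O)cc(C#Cc3cccs3)c12`: > 100000 nM (a limit of the assay)

Compound 3 stands at > 100000 nM, which is a limit of the assay and not a number. Compound 4 `Nc1ncnn2c([C@@H]3O[C@H](CO)[C@@H](O)[C@H]3O)cc(C#Cc3ccccc3)c12` carries phenyl in place of thiophen-2-yl on a triple-bonded carbon. Going by the values given here, two measured steps bear on this change, both large: an at least 90-fold higher number from compound 1 to compound 3 (1.95 log units; beyond the scatter) and an at least 2500-fold higher number from compound 2 to compound 3 (3.39 log units; beyond the scatter). Among the compounds with values here, they concern only the entry of thiophen-2-yl, and no step yet starts from an aromatic ring to another. Phenyl is also an aromatic ring, so compound 4 is expected to stay weak, close to the value of compound 3 at > 100000 nM. The expected change is small, and any measurable number would mean an at least 3.3-fold lower number from compound 3 to compound 4 (0.52 log units; beyond the scatter). For compound 4 the estimated value is 30000 nM, with an expected range of 3000 nM to 100000 nM.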

Compound 4, half-maximal inhibitory concentration: > 100000 nM
Compound 4 ended at the assay's limit (the forecaster's own chance of this, stated with the estimate: 55%); at least 3.3-fold (0.52 log units) between middle value and limit.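

In this assay, phenyl on the triple-bonded carbon falls far behind both cyclopropyl and propyl, with an at least 2500-fold higher number from compound 2 to compound 4 (3.39 log units; beyond the scatter) and an at least 90-fold higher number from compound 1 to compound 4 (1.95 log units; beyond the scatter). The loss seen with thiophen-2-yl therefore recurs with a six-membered aromatic ring of carbon only, so it does not depend on the sulfur atom. The step between phenyl and thiophen-2-yl cannot be read, because both values sit at a limit: the limit of > 100000 nM in this assay, at which 2 of the 4 values shown sit.

Still open, on these data alone, is whether cyclohexyl or a longer chain such as pentyl keeps the activity of compound 2. Also open, as far as these compounds go, is whether an amine at the end of the propyl chain shifts the activity of compound 1.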